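The source may report more compounds than this note shows. Statements on the series, on what has been measured and on what is new or still open speak of the compounds shown alone.

Of the compounds shown here, two of a shared core have been measured in an ADME assay on MCF-10A cells (Homo sapiens) for inhibition, read by MTT assay, with a stated time of 48 h, tested at 2 uM; on this read-out lower numbers stand for less inhibition and higher numbers for more inhibition at the one concentration tested (going by the name of the read-out). Compound 1 `Cc1noc(C)c1-c1ccc2c(c1)C(c1ccccc1)N(Cc1nnc(-c3ccccc3)o1)C(=O)N2C` gives 12.4% in this assay. Compound 2 `Cc1noc(C)c1-c1ccc2c(c1)C(c1ccccc1)N(Cc1csc(-c3ccc(F)cc3)n1)C(=O)N2C` gives 6.8% in this assay, the lower of the two numbers, and the step of a number 5.6 percentage points lower from compound 1 to compound 2 (within the scatter) is within the scatter, so the two compounds cannot be ordered on these data.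

Compound 3 `Cc1noc(C)c1-c1ccc2c(c1)C(c1ccccc1)N(Cc1nnc(-c3ccc(F)cc3)o1)C(=O)N2C` has not been measured. It differs from compound 2 by 5-(4-fluorophenyl)-1,3,4-oxadiazol-2-yl in place of 2-(4-fluorophenyl)-1,3-thiazol-4-yl on a saturated chain carbon bound to an amide-type nitrogen in a ring. Among the measured compounds shown here, the only measured step that bears on this change is a number 5.6 percentage points lower from compound 1 to compound 2 (within the scatter), which exchanged a phenyl-bearing oxadiazole for a fluorophenyl-bearing thiazole and did not move the read-out beyond the scatter. Compound 3 carries the oxadiazole of compound 1 together with the fluorophenyl of compound 2; neither element has shown an effect beyond the scatter here, so the step is expected to be a number 3.2 percentage points higher from compound 2 to compound 3 (within the scatter), that is, none beyond the scatter. For compound 3 the estimate in this assay is 10%, with a range from 0% to 25%.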

Compound 3, a percentage reported as inhibition, at one concentration (the size of the read-out at that concentration, not a potency): 0.7%
For compound 3 the middle estimate is 9.3 percentage points above the measured one, within the range that was stated.
By their numbers in this assay, from the lowest: compounds 3, 2 and 1 (each within the scatter of the next, the first and the last beyond it).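

In this assay, with the 1,3,4-oxadiazole held in place, fluoro in place of hydrogen on an aromatic carbon gives a number 11.7 percentage points lower from compound 1 to compound 3 (beyond the scatter), the first single change among these compounds to pass the scatter. The earlier step changed the five-membered ring and the fluoro together, whereas the new pairs separate them. Exchanging the ring alone, with the 4-fluorophenyl kept, gives a number 6.1 percentage points lower from compound 2 to compound 3 (within the scatter), so the 5-(4-fluorophenyl)-1,3,4-oxadiazol-2-yl and the 2-(4-fluorophenyl)-1,3-thiazol-4-yl cannot be ordered on a saturated chain carbon bound to an amide-type nitrogen in a ring, and nothing given here explains the step seen with fluoro.

The compounds shown leave open whether fluoro in place of hydrogen would produce a step of similar size on the thiazole-bearing compounds, as the one readable fluoro step comes from a single pair on the oxadiazole. They also leave open how a chloro group, a methoxy group or an amine on that same aromatic carbon would compare with fluoro in this read-out.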